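Ring size on the imidazole nitrogen: cyclopropyl to cyclopentyl

A few compounds are considered here, and "the series" means these few. Any claim that something is new, unique, unknown or untested is made for them only; others in the source may bear on it.

Measured so far in a functional assay on SK-OV-3 cells (Homo sapiens) for cytotoxicity; a higher number here means a weaker inhibitor, a lower number a stronger inhibitor:
compound 1 `O=C(CCCCCCc1nc2ccccc2[nH]1)NO` gives 2700 nM
compound 2 `Cn1c(CCCCCCC(=O)NO)nc2ccccc21` gives 3000 nM
compound 3 `O=C(CCCCCCc1nc2ccccc2n1C1CC1)NO` gives 9500 nM

Compound 3 has the highest number of the three in this assay. Its nearest neighbour is compound 2, as the step of a 3.2-fold higher number from compound 2 to compound 3 (0.50 log units; beyond the scatter) shows, and its furthest is compound 1, by a 3.5-fold higher number from compound 1 to compound 3 (0.55 log units; beyond the scatter); both steps are modest but beyond the scatter. The step from compound 1 to compound 2, a 1.1-fold higher number from compound 1 to compound 2 (0.05 log units; within the scatter), is within the scatter.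

Compound 4 `O=C(CCCCCCc1nc2ccccc2n1C1CCCC1)NO` differs from compound 3 in one place: cyclopentyl in place of cyclopropyl on an aromatic nitrogen. The two steps that bear on this change are the ones to compound 3 from compound 1 and from compound 2: each time a larger group on the aromatic nitrogen went with a modest rise in the number. Cyclopentyl in place of cyclopropyl continues in that direction, so a further modest rise, or at most a step at the edge of the scatter, is expected for compound 4, namely a 1.5-fold higher number from compound 3 to compound 4 (0.17 log units; within the scatter). Compound 4 is therefore estimated at 14000 nM, with a range from 6000 nM to 35000 nM.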

Compound 4, half-maximal inhibitory concentration: 4800 nM
Compound 4: the middle estimate sits 2.9-fold (0.46 log units) above what was measured, outside the stated range (below it).
By their numbers in this assay, from the lowest: compounds 1, 2, 4 and 3 (each within the scatter of the next, the first and the last beyond it).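

In this assay, exchanging cyclopropyl for cyclopentyl on the aromatic nitrogen gives a step within the scatter (a 2.0-fold lower number from compound 3 to compound 4 (0.30 log units; within the scatter)), so these two ring sizes cannot be told apart at this position. Cyclopentyl also stays within the scatter when set against methyl (a 1.6-fold higher number from compound 2 to compound 4 (0.20 log units; within the scatter)) and against hydrogen (a 1.8-fold higher number from compound 1 to compound 4 (0.25 log units; within the scatter)), so the largest group shown here carries no readable penalty. Among these compounds, compound 4 therefore goes against any steady rise with group size, leaving compound 3 as the only compound beyond the scatter of compounds 1 and 2, and nothing available explains this.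

Going by these compounds, whether a cyclobutyl or cyclohexyl ring would also stay within the scatter of compound 1 remains open. So does the outcome for a phenyl ring or a chain ending in an amine on this nitrogen.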